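Aryl-substituted series in the NF-kappa-B inhibition read-out

The compounds below may be only part of what the source reports. "The series", "measured", "known", "first", "only" and "open" are said of these compounds alone.

In an assay on FRT-Jurkat cells for inhibition of nuclear factor NF-kappa-B complex (Homo sapiens), read by flow cytometry, with a stated time of 24 h, tested at 10 uM (on this read-out higher numbers stand for more inhibition at the one concentration tested (going by the name of the read-out) and lower numbers for less inhibition), compound 1 `COc1ccc(Nc2cccc3c2C(=O)N(C2CCC(=O)NC2=O)C3=O)cc1` gives 13%. Compound 2 `O=C1CCC(N2C(=O)c3ccc(Nc4ccc(O)cc4)cc3C2=O)C(=O)N1` gives 4% and compound 3 `CCCc1ccc(Nc2ccc3c(c2)C(=O)N(C2CCC(=O)NC2=O)C3=O)cc1` gives 10%; the gaps from compound 1 to either of them are within the scatter, so none of the three stands apart from the others on this assay, and all sit at a low level of inhibition.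

Compound 4 `CC(C)(C)c1ccc(Nc2cccc3c2C(=O)N(C2CCC(=O)NC2=O)C3=O)cc1` differs from compound 1 by tert-butyl in place of methoxy on an aromatic carbon. Among the compounds with values here, the one measured step that resembles this change, an alkyl entering where an oxygen-bearing group sat on an aromatic carbon, is a number 6 percentage points higher from compound 2 to compound 3 (within the scatter), a move within the scatter. Within the data shown here, on that basis, and with no other relevant step in hand, no change beyond the scatter is expected for this assay from compound 1 to compound 4; the step is estimated at a number 2 percentage points higher from compound 1 to compound 4 (within the scatter). Compound 4 is therefore expected to give about 15%, within a range of 3% to 28%.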

Compound 4, a percentage reported as inhibition, at one concentration (the size of the read-out at that concentration, not a potency): 36%
For compound 4 the middle estimate is 21 percentage points below the measured one, and the stated range ends below it.
By their numbers in this assay, from the lowest: compounds 2, 3 and 1 (each within the scatter of the next); then compound 4.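

In this assay, within the data shown here, the change from 4-methoxyphenyl to 4-(tert-butyl)phenyl gives the first step in this set that lies beyond the scatter: a number 23 percentage points higher from compound 1 to compound 4 (beyond the scatter). The only earlier step, a number 6 percentage points higher from compound 2 to compound 3 (within the scatter), stayed within the scatter, so the read-out is now shown to respond to the group at this place, para to a large group, on the core of compound 1. Nothing measured here accounts for the size of this step.

Open, going by these compounds, is how an isopropyl group, a longer chain or an amine would read at this same place, and so whether the rise is particular to tert-butyl or extends to other groups. With one concentration tested, these numbers also leave the potency of compound 4 open.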